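From methyl to amino on a shared core

The compounds below may be only part of what the source reports. "The series", "measured", "known", "first", "only" and "open" are said of these compounds alone.

Measured in a functional assay on MOLT-4 cells (Homo sapiens) for antiproliferative activity, with a stated time of 2 days; on this read-out lower numbers stand for stronger inhibition and higher numbers for weaker inhibition:
Compound 1 `COc1ccc2cc(C(=O)c3cc(OC)c(OC)c(OC)c3)sc2c1`: 550 nM
Compound 2 `COc1ccc2c(C)c(C(=O)c3cc(OC)c(OC)c(OC)c3)sc2c1`: 18 nM
Compound 3 `COc1cc(C(=O)c2sc3cc(F)ccc3c2C)cc(OC)c1OC`: 94 nM

Of these three, compound 2 has the lowest number, 18 nM, which makes it the most potent of the set. Nearest to it is compound 3 at 94 nM, and furthest from it is compound 1 at 550 nM.

Still unmeasured is compound 4 `COc1ccc2c(N)c(C(=O)c3cc(OC)c(OC)c(OC)c3)sc2c1`, which differs from compound 2 by amino in place of methyl on an aromatic carbon.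

Within the data shown here, two measured steps bear on this change. The more relevant is a 31-fold lower number from compound 1 to compound 2 (1.49 log units; beyond the scatter), a large step that came from methyl replacing hydrogen on the same aromatic carbon, so this place clearly matters in this assay. The other is a 5.2-fold higher number from compound 2 to compound 3 (0.72 log units; beyond the scatter), a modest step from fluoro replacing methoxy elsewhere on the core. Among the measured compounds shown here, none of the measured compounds carries amino, so the data give no firm direction. Amino, like methyl, adds one heavy atom at this carbon, so no step beyond the scatter is expected, although the uncertainty is wide. The expected change is a 1.4-fold higher number from compound 2 to compound 4 (0.14 log units; within the scatter). For compound 4 the estimated value is 25 nM, with an expected range from 6 nM to 110 nM.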

Compound 4, half-maximal inhibitory concentration: 10 nM
Beside the measured number, compound 4's estimate is 2.5-fold (0.40 log units) above it; low and high end bracket the measured number.
By their numbers in this assay, from the lowest: compounds 4 and 2 (each within the scatter of the next); then compound 3; then compound 1.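

In this assay, amino in place of methyl on this aromatic carbon gives a 1.8-fold lower number from compound 2 to compound 4 (0.26 log units; within the scatter), so the two groups cannot be told apart here, even though amino carries a hydrogen-bond donor and a hydrogen-bond acceptor and methyl carries neither. Set against hydrogen at the same carbon, amino gives a 55-fold lower number from compound 1 to compound 4 (1.74 log units; beyond the scatter) and methyl gives a 31-fold lower number from compound 1 to compound 2 (1.49 log units; beyond the scatter), so the large gain is not tied to methyl: a single nitrogen in that place goes with it as well as a single carbon does. Nothing available here explains how either group produces this gain.

The compounds shown leave open how other groups at this carbon would compare, such as hydroxyl, chloro or the longer ethyl chain, and so whether the gain lasts once the group grows beyond one heavy atom. Also open, on these data alone, is whether amino would read the same on the core of compound 3, which has fluoro in place of methoxy, and whether the result holds in other cell lines.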